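Swapping the Benzyl Group: Fluorine Out, Nitrile In

The source may hold more compounds than are shown below. What is called first, only, known or untested is meant among the compounds shown, and "the series" means these compounds.

Two measured compounds share a common core and differ only in the group attached on a saturated chain carbon bound to an oxygen on an aromatic ring. Compound 1 `C=CCOn1c(-c2cccc(C#N)c2)nc(C)c1C(=O)OCC` carries a vinyl there, and compound 2 `CCOC(=O)c1c(C)nc(-c2cccc(C#N)c2)n1OCc1cccc(F)c1` carries a 3-fluorophenyl. In a functional assay on a cell-free system (plasma, Oryctolagus cuniculus) for inhibition, with stated times of 5 min, 1 min and 6 min (a lower number here means a stronger inhibitor, a higher number a weaker inhibitor), compound 1 gives 5860 nM, while compound 2 gives 22400 nM, the higher of the two numbers; the step of a 3.8-fold higher number from compound 1 to compound 2 (0.58 log units; beyond the scatter).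

Compound 3 `CCOC(=O)c1c(C)nc(-c2cccc(C#N)c2)n1OCc1ccccc1C#N` differs from compound 2 by 2-cyanophenyl in place of 3-fluorophenyl on a saturated chain carbon bound to an oxygen on an aromatic ring. Among the measured compounds shown here, no measured pair exchanges one aromatic ring for another, and the only step recorded, a 3.8-fold higher number from compound 1 to compound 2 (0.58 log units; beyond the scatter), swaps a vinyl for an aromatic ring, so it bears only loosely on this change. Both compound 2 and compound 3 keep an aromatic ring at that place, so compound 3 is expected to move little: a 1.5-fold lower number from compound 2 to compound 3 (0.17 log units; within the scatter), within the scatter. Compound 3 is estimated at 15000 nM in this assay, ranging from 5000 nM to 50000 nM.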

Compound 3, half-maximal inhibitory concentration: 9380 nM
Beside the measured number, compound 3's estimate is 1.6-fold (0.20 log units) above it; low and high end bracket the measured number.
By their numbers in this assay, from the lowest: compounds 1 and 3 (each within the scatter of the next); then compound 2.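

Among the compounds shown here, replacing 3-fluorophenyl with 2-cyanophenyl gives a 2.4-fold lower number from compound 2 to compound 3 (0.38 log units; beyond the scatter) in this assay, the first comparison of one aromatic ring with another at this place, and it shows that the choice of ring can shift the number beyond the usual scatter. An aromatic ring on this chain carbon does not always give a higher number than vinyl, as changing vinyl to 2-cyanophenyl gives a 1.6-fold higher number from compound 1 to compound 3 (0.20 log units; within the scatter), which stays within the scatter. No measurement here explains why the two rings differ.

Compounds 2 and 3 differ both in the group on the ring and in the number in its name, so 2-fluorophenyl and 3-cyanophenyl would be needed to tell those two changes apart. From the compounds shown here alone, how an amine or a carboxylic acid at this place would read also remains open.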